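Swapping the Thioether Aryl Group for an Imidazoline Ring

The compounds below may be only part of what the source reports. "The series", "measured", "known", "first", "only" and "open" are said of these compounds alone.

Compound 1, `N#Cc1c(N)nc(SCc2cccnc2)c(C#N)c1-c1ccc(OCC2CC2)cc1`: 67 nM
Compound 2, `COC(=O)c1cccc(CSc2nc(N)c(C#N)c(-c3ccc(OCC4CC4)cc3)c2C#N)c1`: 66 nM

In an assay on CHO cells for displacement of a labelled ligand from adenosine receptor A1 (Homo sapiens), read by scintillation counting, with a stated time of 90 min (a lower number here means a stronger inhibitor, a higher number a weaker inhibitor), compound 2 gives 66 nM, and compound 1 gives 67 nM, the two numbers lying within the scatter of each other. Compound 3, `N#Cc1c(N)nc(SCC2=NCCN2)c(C#N)c1-c1ccc(OCC2CC2)cc1`, differs from compound 2 by a group of 5 heavy atoms (3 carbon, 2 nitrogen; one five-membered non-aromatic ring with 2 hetero atoms) in place of a group of 10 heavy atoms (8 carbon, 2 oxygen; one six-membered aromatic ring of carbon only), on a saturated chain carbon bound to a sulfur. For the measured compounds named here, the one measured step, a 1.0-fold lower number from compound 1 to compound 2 (0.01 log units; within the scatter), exchanged one aromatic group for another at the same place without moving this assay; no measured step replaces the aromatic ring with a non-aromatic one. Compound 3 is therefore expected to give 120 nM (range 40 nM to 400 nM), an expected step of a 1.8-fold higher number from compound 2 to compound 3 (0.26 log units; within the scatter), close to the scatter.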

Compound 3, inhibition constant: 483 nM
For compound 3 the middle estimate is 4.0-fold (0.60 log units) below the measured one; measured number above the stated range.
By their numbers in this assay, from the lowest: compounds 2 and 1 (each within the scatter of the next); then compound 3.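

Placed on a saturated chain carbon bound to a sulfur, the five-membered non-aromatic ring with 2 hetero atoms gives the first change at this position that lies beyond the scatter in this assay (a 7.3-fold higher number from compound 2 to compound 3 (0.86 log units; beyond the scatter); a 7.2-fold higher number from compound 1 to compound 3 (0.86 log units; beyond the scatter)). This position therefore does not treat every group alike, although the aromatic groups of compound 1 and compound 2 could not be told apart. Nothing available accounts for this weakening.

The compounds shown leave open whether the aromatic ring itself matters or whether the entering ring is what weakens binding. A cyclohexyl group or a simple amine at this place could separate the two.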